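Swapping Cyano for Nitro in an Antiproliferative Amide Series

The compounds below may be only part of what the source reports. "The series", "measured", "known", "first", "only" and "open" are said of these compounds alone.

Of the compounds shown here, three built around an aromatic amide have been tested in a functional assay on SK-HEP1 cells (Homo sapiens) for antiproliferative activity, read by sulforhodamine B assay; on this read-out lower numbers stand for stronger inhibition of growth and higher numbers for weaker inhibition of growth. For the measured compounds named here, compound 1, `Cc1cc(C)c2sc(NC(=O)c3ccc(C#N)cc3)nc2c1`, is the only one that yields a number: in this assay compound 1 gives 1.18 ug/mL. Compound 2, `COc1cccc2sc(NC(=O)c3ccc(C#N)cc3)nc12`, reaches only a limit of the assay, > 10 ug/mL in this assay. Compound 3, `COc1cccc2sc(NC(=O)c3ccc([N+](=O)[O-])cc3)nc12`, likewise reaches only a limit, > 10 ug/mL in this assay. The difference between the core of compound 1 and the core of compound 2 is not broken down here.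

Compound 3 differs from compound 2 by nitro in place of cyano on an aromatic carbon. The step that the two limits leave unreadable from compound 2 to compound 3 cannot be given a size, as both of its end points sit at the limit of > 10 ug/mL in this assay, at which 2 of the 3 values shown sit. That measured instance of the change therefore says nothing about whether growth inhibition moves up or down when nitro replaces cyano.

Compound 4, `Cc1cc(C)c2sc(NC(=O)c3ccc([N+](=O)[O-])cc3)nc2c1`, has not yet been measured. Going by the values given here, it differs from compound 1 by nitro in place of cyano on an aromatic carbon, the same change as the one between compound 2 and compound 3, made on the core that gave a number. With no readable size from the measured pair, the expectation rests on the value of compound 1, 1.18 ug/mL, and on an assumed small step. Compound 4 is expected to show a step of a 1.3-fold higher number from compound 1 to compound 4 (0.10 log units; within the scatter) in this assay. Compound 4 is thus estimated at 1.5 ug/mL in this assay, with a plausible range from 0.5 ug/mL to 6 ug/mL.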

Compound 4, concentration for 50% growth inhibition: 1.74 ug/mL
Compound 4: middle estimate off by 1.2-fold (0.06 log units), on the low side, and the stated range covers the measured number.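

On the core of compound 1, putting nitro in place of cyano gives a 1.5-fold higher number from compound 1 to compound 4 (0.17 log units; within the scatter) in this assay, so the two compounds cannot be told apart on this read-out. The same change on the other core, from compound 2 to compound 3, cannot be read, so no size stands beside the new step and nothing shows how the change behaves on a second core: the limit of > 10 ug/mL in this assay, at which 2 of the 4 values shown sit. What the series does show is narrower: one pair, on one core, in which nitro can stand in place of cyano without a difference beyond the usual scatter, and this single pair is no rule for other cores and gives no reason for the result.

The compounds shown leave open how an amine or a carboxylic acid at that same place on the core of compound 1 would read in this assay, as cyano and nitro are the only two groups seen there. They also leave open whether any group at that place could bring the core of compound 2 from a limit of the assay to a readable number.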